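Configuration step in the ethyl compound series

This account rests on a few compounds, and the source may have more. Where it says the series, first, only, none or still open, it means among the compounds named here.

Values measured so far in an ADME assay on L6 cells (Rattus norvegicus) for cytotoxicity, read by resazurin assay, with a stated time of 70 h (a lower number here means that less compound is needed, a higher number that more compound is needed for the effect), are these
- compound 1 `CC(C)[C@H]1CC[C@@H](n2c(=O)[nH]c3ncc(N)cc3c2=O)CC1` gives 46000 nM here
- compound 2 `CC[C@H]1CC[C@H](n2c(=O)[nH]c3ncc(N)cc3c2=O)CC1` gives 51000 nM here

Compound 1 and compound 2 lie within the scatter of each other, so the two values place neither compound ahead. Among the measured compounds shown here, compound 2, at 51000 nM in this assay, therefore stands level with the only other measured compound, and both numbers say that a lot of compound is needed for the effect.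

The next compound is compound 3 `CC[C@H]1CC[C@@H](n2c(=O)[nH]c3ncc(N)cc3c2=O)CC1`, not yet measured. Its change from compound 2 is purely one of drawn configuration: the two compounds have the same atoms and bonds and differ only in configuration as drawn: 2 of 2 stereo elements differ (all stereocentres are inverted: mirror images); a stereocentre at a saturated ring carbon is drawn r in compound 2 and s in compound 3; a stereocentre at a saturated ring carbon is drawn r in compound 2 and s in compound 3. Both stereocentres at saturated ring carbons are inverted, while atoms and bonds stay the same.

For the measured compounds named here, no measured pair isolates a change of configuration, so the data give no direct guide to this step. The expected 1.1-fold lower number from compound 2 to compound 3 (0.03 log units; within the scatter) is small, with no shift beyond the scatter expected in either direction. In this assay compound 3 is estimated at 48000 nM with an expected range from 20000 nM to 100000 nM as its ends.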

Compound 3, half-maximal effective concentration in the L6 assay: 250000 nM
Beside the measured number, compound 3's estimate is 5.2-fold (0.72 log units) below it, and the stated range ends below it.
By their numbers in the L6 assay, from the lowest: compounds 1 and 2 (each within the scatter of the next); then compound 3.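

In the L6 assay the ring stereocentres turn out to matter, a point the level values of compound 1 and compound 2 could not show: inverting both gives a 4.9-fold higher number from compound 2 to compound 3 (0.69 log units; beyond the scatter), and compound 3 also separates from the other measured compound, with a 5.4-fold higher number from compound 1 to compound 3 (0.74 log units; beyond the scatter), and the first of these steps can be assigned to configuration alone because of this: the fact that compounds 2 and 3 differ only in the configuration as drawn

In a physicochemical assay for solubility, read by nephelometry, measured as kinetic solubility (a higher number here means a more soluble compound, a lower number a less soluble compound), compound 2 gives 55000 nM. In the physicochemical assay compound 3 gives < 17000 nM, which is a limit of the assay and not a number: the limit of < 17000 nM in the physicochemical assay, at which 1 of the 2 values shown sits.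

The same inversion therefore separates the mirror-image pair in the physicochemical assay as well, with an at least 3.2-fold lower number from compound 2 to compound 3 (0.50 log units; beyond the scatter), so the two assays move in a way that makes compound 3 differ from compound 2 on both read-outs.

Open, on these data alone, is whether inverting the ring stereocentres gives a step of this size when the ring carries the substituent of compound 1 rather than ethyl. Also open, as far as these compounds go, is whether a longer chain or a carboxylic acid in place of the ethyl group would keep the same difference between the two configurations in either assay.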